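The compounds below may be only part of what the source reports. "The series", "measured", "known", "first", "only" and "open" are said of these compounds alone.

Of the compounds shown here, two built on one shared core have been measured so far. Compound 1 `Cc1cc(Cl)nc(NC(=S)NC(=O)c2c(-c3ccc(Cl)cc3Cl)noc2C)n1` carries a chloro on an aromatic carbon, and in a functional assay on the whole organism for inhibition, with Brassica napus as the target, with a stated time of 72 h, tested at 100 mg/L (a lower number here means less inhibition of growth, a higher number more inhibition of growth at the concentration tested), compound 1 gives 50.8%. Compound 2 `Cc1cc(C)nc(NC(=S)NC(=O)c2c(-c3ccc(Cl)cc3Cl)noc2C)n1` carries a methyl in place of that chloro, and in this assay compound 2 gives 68%. Among the compounds with values here, the one measured step, a number 17.2 percentage points higher from compound 1 to compound 2 (beyond the scatter), lies beyond the scatter, so compound 2 stands highest of the two numbers, with compound 1 as its nearest neighbour.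

Compound 3 `COc1cc(OC)nc(NC(=S)NC(=O)c2c(-c3ccc(Cl)cc3Cl)noc2C)n1` has not yet been measured. It differs from compound 2 in one place: 4,6-dimethoxypyrimidin-2-yl in place of 4,6-dimethylpyrimidin-2-yl on an amide-type nitrogen. Within the data shown here, the only measured step exchanged a chloro for a methyl on an aromatic carbon, a change of a different kind from the one leading to compound 3, so no measured pair covers the exchange of methyl for methoxy. The direction is therefore open, and in this assay the expectation is a step of either sign or none beyond the scatter. Compound 3 is expected to give about 60%, within 35% to 85%. The step this estimate implies is a number 8 percentage points lower from compound 2 to compound 3 (within the scatter).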

Compound 3, percent growth inhibition at one concentration: 70.8%
The estimate for compound 3 lay 10.8 percentage points below the measured number; low and high end bracket the measured number.
By their numbers in this assay, from the lowest: compound 1; then compounds 2 and 3 (each within the scatter of the next).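

In this assay, 4,6-dimethoxypyrimidin-2-yl in place of 4,6-dimethylpyrimidin-2-yl on the amide-type nitrogen gives a number 2.8 percentage points higher from compound 2 to compound 3 (within the scatter) and so cannot be told apart from it at this position, although the entering group adds two oxygen atoms and two hydrogen-bond acceptors. Against the 4-chloro-6-methylpyrimidin-2-yl group of compound 1, the same dimethoxy group gives a number 20 percentage points higher from compound 1 to compound 3 (beyond the scatter) and thus stands clear of the scatter, so among these three compounds only compound 1 is set apart, while compound 2 and compound 3 sit together. Nothing measured here bears on what lies behind these numbers.

The three compounds do not show whether this level of growth inhibition would hold with a larger or differently built group at this position, such as 4,6-diethoxypyrimidin-2-yl with its longer chains or 4,6-diaminopyrimidin-2-yl with its amines. They also leave open whether a mixed 4-methoxy-6-methylpyrimidin-2-yl group would sit with compound 2 and compound 3, and how any of these groups would behave at a different concentration or in another plant.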